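A few compounds are considered here, and "the series" means these few. Any claim that something is new, unique, unknown or untested is made for them only; others in the source may bear on it.

Compound 2, `C[C@@H]1C[C@@H]1C(=O)N1CC2CC(C1)N2`, is the weaker of the two measured compounds: in an assay on SH-EP1 cells for agonist activity at Neuronal acetylcholine receptor; alpha4/beta2 (Homo sapiens), read by FLIPR and calcium flux (on this read-out higher numbers stand for larger maximal responses and lower numbers for smaller maximal responses), compound 2 reaches 88%, the lowest of the two numbers, while compound 1, `CCCC(=O)N1CC2CC(C1)N2`, reaches 120%. Within the data shown here, the single measured step, a number 32 percentage points lower from compound 1 to compound 2 (beyond the scatter), exchanges a group of 3 heavy atoms with no ring for a group of 4 heavy atoms containing one three-membered non-aromatic ring of carbon only, on a carbonyl carbon.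

Compound 3, `C[C@@H]1C[C@H]1C(=O)N1CC2CC(C1)N2`, differs from compound 2 only in configuration: the two compounds have the same atoms and bonds; at least one stereo element is drawn with a configuration in one of them and without one in the other: 1 of 4 stereo elements differ; a stereocentre at a saturated ring carbon is drawn S in compound 2 and R in compound 3. Among the measured compounds shown here, no measured step bears on such a change; the step from compound 1 to compound 2 concerns the atoms attached to the carbonyl carbon, not the arrangement at a saturated ring carbon, so it gives no direction for compound 3. The expected step is therefore a number 2 percentage points higher from compound 2 to compound 3 (within the scatter), meaning no change beyond the scatter, with a wide uncertainty in either direction. Compound 3 is expected to give about 90% in this assay, within a range from 55% to 125%.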

Compound 3, largest response reached (Emax), in percent of the reference or control that the assay uses: 110%
The estimate for compound 3 lay 20 percentage points below the measured number; the range from low to high includes it.
By their numbers in this assay, from the lowest: compound 2; then compounds 3 and 1 (each within the scatter of the next).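

With the atoms and bonds unchanged, the arrangement at a saturated ring carbon of the 2-methylcyclopropyl group proves to matter in this assay (a number 22 percentage points higher from compound 2 to compound 3 (beyond the scatter)), something the earlier comparison of a propyl group with a ring-bearing group could not separate. The ring group itself therefore does not go with a lower number in every arrangement, since 2-methylcyclopropyl in place of propyl on a carbonyl carbon gives no difference beyond the scatter in one of the two arrangements (a number 10 percentage points lower from compound 1 to compound 3 (within the scatter)), so the earlier fall is tied to the arrangement found in compound 2 among these compounds. This reading of the step as a matter of configuration alone rests on a single point of comparison: the fact that one of compounds 2 and 3 is drawn with a defined configuration and the other without, at the place where they differ.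

The compounds shown leave open how a change at the remaining stereocentre of the 2-methylcyclopropyl group would read in this assay. They also leave open whether the same sensitivity to arrangement holds for a cyclobutyl group, a longer chain or an amine on the carbonyl carbon.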